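A few compounds are considered here, and "the series" means these few. Any claim that something is new, unique, unknown or untested is made for them only; others in the source may bear on it.

Measured compounds:
Compound 1 `COc1cc(-c2nn(-c3cccc(NC(=O)Nc4cccc(C(F)(F)F)c4)c3)cc2-c2ccncc2)ccc1Cl` gives 3480 nM in a functional assay on MOLT-4 cells (Homo sapiens) for inhibition, read by sulforhodamine B assay, with a stated time of 48 h; on this read-out higher numbers stand for weaker inhibition of growth and lower numbers for stronger inhibition of growth.
Compound 2 `COc1cc(-c2nn(-c3cccc(NC(=O)c4ccc(Cl)c(C(F)(F)F)c4)c3)cc2-c2ccncc2)ccc1Cl` gives > 32500 nM in this assay, which is a limit of the assay and not a number.

Compound 2 stands at the weak end of the two results shown; all that is known of it is the limit of > 32500 nM in this assay, at which 1 of the 2 values shown sits, so only a bound exists for it. Within the data shown here, the one measured step, from compound 1 to compound 2, in which a urea link becomes an amide link, gave an at least 9.3-fold higher number from compound 1 to compound 2 (0.97 log units; beyond the scatter).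

Compound 3 `COc1cc(-c2nn(-c3cccc(NC(=O)Nc4ccc(Cl)c(C(F)(F)F)c4)c3)cc2-c2ccncc2)ccc1Cl` has not yet been measured. It differs from compound 2 in a single place: (4-chloro-3-(trifluoromethyl)phenyl)amino in place of 4-chloro-3-(trifluoromethyl)phenyl on a carbonyl carbon. This change brings back the urea link of compound 1 while keeping the aryl group of compound 2. Among the measured compounds shown here, the only measured step that bears on it is the one from compound 1 to compound 2, which ran the other way, from urea to amide, and was at least modest in size. Reversing that kind of change is therefore expected to lower the number in this assay by a step of roughly comparable size. Compound 3 is accordingly estimated at 3500 nM, within a range from 1000 nM to 12000 nM. The expected step is an at least 9.2-fold lower number from compound 2 to compound 3 (0.96 log units; beyond the scatter).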

Compound 3, concentration for total growth inhibition: 7960 nM
Compound 3: middle estimate off by 2.3-fold (0.36 log units), on the low side, and the stated range covers the measured number.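

In this assay, with the 4-chloro-3-(trifluoromethyl)phenyl group held fixed, putting the nitrogen of the urea link back on the carbonyl carbon gave an at least 4.0-fold lower number from compound 2 to compound 3 (0.61 log units; beyond the scatter), so the urea and amide links are now compared with nothing else changed. The earlier step had changed the link and the aryl group together, whereas the urea pair now isolates the chloro on an aromatic carbon, which gave a 2.3-fold higher number from compound 1 to compound 3 (0.36 log units; beyond the scatter) and so is not a silent addition in this series. The size of the link step remains a floor, since the result for compound 2 is a limit of the assay and not a number: the limit of > 32500 nM in this assay, at which 1 of the 3 values shown sits.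

The compounds shown leave open how an amide carrying the 3-(trifluoromethyl)phenyl group alone would read, and so whether the chloro has the same effect on the amide side as on the urea side. They also leave open whether a thiourea link in place of the urea, or a fluoro or methyl group in place of the chloro, would give a number nearer that of compound 1 or of compound 3.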